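The source may report more compounds than this note shows. Statements on the series, on what has been measured and on what is new or still open speak of the compounds shown alone.

Measured so far in an ADME assay on microsomes from liver (Rattus norvegicus) for metabolic stability; on this read-out higher numbers stand for a longer-lived compound and lower numbers for a shorter-lived compound:

compound 1, `CN1C(=O)COc2cc(Nc3ccc4ncn(CC5CC5)c4n3)cnc21`: 0.117 h
compound 2, `Cc1cc(Nc2cnc3c(c2)OCC(=O)N3C)nc2c1ncn2CC1CC1`: 0.367 h
compound 3, `CN1C(=O)COc2cc(Nc3cc4c(cc3F)ncn4CC3CC3)cnc21`: 0.283 h

Compound 1 and compound 2 differ in one place, (methyl in place of hydrogen on an aromatic carbon), and this gives a 3.1-fold higher number from compound 1 to compound 2 (0.50 log units; beyond the scatter). Compound 3 carries a different core from compound 1; the difference between the two cores is not broken down here. Its values show compound 3 with the higher number of the two, beyond the scatter. Against compound 2 the value of compound 3 lies within the scatter, so nothing separates them in this assay.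

Compound 4, `Cc1c(F)c(Nc2cnc3c(c2)OCC(=O)N3C)cc2c1ncn2CC1CC1`, is not yet measured. It arises from compound 3 by methyl in place of hydrogen on an aromatic carbon. This is the same kind of change as the one from compound 1 to compound 2, and it is seen twice among these compounds, but the surroundings differ: in compound 2 the methyl sits on a six-membered aromatic ring with 1 nitrogen, opposite the ring nitrogen, whereas in compound 4 it sits on a six-membered aromatic ring of carbon only, ortho to a fluoro group. Beside a 3.1-fold higher number from compound 1 to compound 2 (0.50 log units; beyond the scatter), the step of a 1.9-fold higher number from compound 3 to compound 4 (0.29 log units; within the scatter) is expected for compound 4, an increase of similar direction but tempered because only one measured step, a 3.1-fold higher number from compound 1 to compound 2 (0.50 log units; beyond the scatter), supports it and the place is not the same. Compound 4 is therefore estimated at 0.55 h, with a range from 0.25 h to 1.2 h.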

Compound 4, half-life: 0.917 h
Compound 4: middle estimate off by 1.7-fold (0.22 log units), on the low side, and the stated range covers the measured number.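

In this assay, methyl in place of hydrogen on an aromatic carbon gives a 3.2-fold higher number from compound 3 to compound 4 (0.51 log units; beyond the scatter), a step beyond the scatter on the core of compound 3. Set beside the earlier step, the change carries from one core to the other with no difference in size that can be told apart: the same change on two cores in this assay, a 3.1-fold higher number (0.50 log units; beyond the scatter) from compound 1 to compound 2 and a 3.2-fold higher number (0.51 log units; beyond the scatter) from compound 3 to compound 4, 1.0-fold (0.01 log units) apart, within the scatter of two such steps This agreement holds even though the methyl sits in different surroundings, on a six-membered aromatic ring with 1 nitrogen in compound 2 and on a six-membered aromatic ring of carbon only, ortho to a fluoro group, in compound 4, but two steps on two cores show only that the change transferred here, not that it will do so on any further core, and they do not show how the methyl produces the longer half-life.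

The compounds shown leave open whether the step is particular to methyl or would also appear with an ethyl group, a methoxy group, a chlorine atom or a nitrile on the same aromatic carbon. They also leave open whether the step on the core of compound 3 would remain if the fluoro group were replaced by hydrogen or by chlorine.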